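Removing the bromo group from compound 2

The compounds below may be only part of what the source reports. "The series", "measured", "known", "first", "only" and "open" are said of these compounds alone.

Of the compounds shown here, three with related structures have been tested in a functional assay on the whole organism with Mus musculus as the target; on this read-out lower numbers stand for an effect already at smaller amounts and higher numbers for an effect only at larger amounts of compound. Compound 1 `COc1cc2c(cc1OC)C(c1cccc(N)c1)=NN=C(S)C2` gives 9.1 umol/kg. Compound 2 `COc1cc2c(cc1OC)C(c1ccc(Br)cc1)=NN(C)C(=S)C2` gives 60.4 umol/kg, the higher of the two numbers, and the gap to compound 1 lies beyond the usual scatter. For compound 3 `COc1cc2c(cc1OC)C(c1cccc([N+](=O)[O-])c1)=NNC(=O)C2` the read-out is a limit of the assay, > 120 umol/kg, and not a number.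

Compound 4 `COc1cc2c(cc1OC)C(c1ccccc1)=NN(C)C(=S)C2` has not yet been measured in this assay. Its structure departs from that of compound 2 in one place, with hydrogen in place of bromo on an aromatic carbon. Within the data shown here, no measured pair shows what this change does on its own, so the expectation rests on compound 2 at 60.4 umol/kg. The expected step of a 1.3-fold lower number from compound 2 to compound 4 (0.13 log units; within the scatter) is small and is estimated to stay within the scatter, with no firm direction. For compound 4 the estimated dose is 45 umol/kg, with an expected range from 18 umol/kg to 110 umol/kg.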

Compound 4, dose for half-maximal effect: 24.7 umol/kg
For compound 4 the middle estimate is 1.8-fold (0.26 log units) above the measured one; the measured number falls inside the stated range.
By their numbers in this assay, from the lowest: compound 1; then compound 4; then compound 2. At a limit, above all of these: compound 3.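

The 4-bromophenyl to phenyl change now has a size of its own: in this assay there is a 2.4-fold lower number from compound 2 to compound 4 (0.39 log units; beyond the scatter), and this step lies beyond the usual scatter. The position on the six-membered aromatic ring, para to a large group, therefore responds to what it carries, and the bromo group is not required for a measurable effect in the whole animal. Nothing measured among these compounds bears on the cause of this step.

The compounds shown compare only bromo and hydrogen at this position, so it remains open whether a chloro group, a methyl group or a carboxylic acid there would give a lower or a higher number. Compound 1 and compound 3 differ from compound 4 in more than one place, so they cannot settle this question.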